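Swapping Difluoromethoxy for Isopropyl on a Shared Core

A few compounds are considered here, and "the series" means these few. Any claim that something is new, unique, unknown or untested is made for them only; others in the source may bear on it.

Compound 1 `CC#C[C@@H](CC(=O)O)c1ccc(OCc2ccc3nc(-c4ccc(OC(F)F)cc4)nn3c2)cc1` was tested in an assay on HEK293 cells for agonist activity at Free fatty acid receptor 1 (Homo sapiens), read by a beta-galactosidase reporter and beta-arrestin recruitment, with a stated time of 90 min, in the presence of a further agent that is not named here (a higher number here means a larger maximal response, a lower number a smaller maximal response), where compound 1 gives 127%. This is the higher of the two values at hand. The other measured compound, compound 2 `CC#C[C@@H](CC(=O)O)c1ccc(OCc2ccc3nc(-c4c(C)cc(OCCCS(C)(=O)=O)cc4C)nn3c2)cc1`, gives 114% in this assay, a number that lies beyond the scatter below compound 1. Both compounds reach a largest response above the reference the assay uses. Compound 3 `CC#C[C@@H](CC(=O)O)c1ccc(OCc2ccc3nc(-c4ccc(C(C)C)cc4)nn3c2)cc1` has not yet been measured. It differs from compound 1 in one place: isopropyl in place of difluoromethoxy on an aromatic carbon. Among the compounds with values here, no step between measured compounds that differ in one place is available, so the expectation rests on the two values alone. With the largest response already high in both measured compounds, the step is expected to be small, a modest fall or none beyond the scatter: a number 9 percentage points lower from compound 1 to compound 3 (within the scatter). Compound 3 is expected to give 118%, within a range from 100% to 135%.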

Compound 3, largest response reached (reported as percent of maximum), in percent of the reference or control that the assay uses: 154%
The estimate for compound 3 lay 36 percentage points below the measured number, outside the stated range (above it).
By their numbers in this assay, from the lowest: compound 2; then compound 1; then compound 3.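

In this assay, putting isopropyl in place of difluoromethoxy on the aromatic carbon para to a large group gives a number 27 percentage points higher from compound 1 to compound 3 (beyond the scatter). Within the data shown here, this is the first one-place comparison in the set, and it shows that the group at this position alone can shift the largest response, which had not yet reached its ceiling in compound 1. The change swaps a group of carbon, oxygen and fluorine for one of carbon only, but nothing here shows which of these differences matters.

One step cannot show whether the trend continues with a larger all-carbon group such as tert-butyl, or how a smaller group such as methoxy would compare. It also leaves open whether the same exchange would raise the response on a ring that carries further substituents.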